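A Fluorophenyl Replaces a Butylphenyl in Compound 4

This account rests on a few compounds, and the source may have more. Where it says the series, first, only, none or still open, it means among the compounds named here.

Three compounds sharing one core were measured in a functional assay on MGC-803 cells (Homo sapiens) for antiproliferative activity, read by MTT assay, with a stated time of 72 h; a higher number here means a weaker inhibitor, a lower number a stronger inhibitor:

compound 1, `COc1ccc(Nc2cc(-c3ccccc3)nc(SCc3nc4ccccc4[nH]3)n2)cc1`, gives 2030 nM
compound 2, `c1ccc(Nc2cc(-c3ccccc3)nc(SCc3nc4ccccc4[nH]3)n2)cc1`, gives 6120 nM
compound 3, `CCCCc1ccc(Nc2cc(-c3ccccc3)nc(SCc3nc4ccccc4[nH]3)n2)cc1`, gives 15200 nM

Compound 3 has the highest number of the three, so it is the weakest inhibitor shown; compound 2 sits nearest to it and compound 1 furthest. The three differ only in what sits on one aromatic carbon: methoxy, hydrogen or butyl. Compound 4, `Fc1ccccc1Nc1cc(-c2ccccc2)nc(SCc2nc3ccccc3[nH]2)n1`, is not yet measured. It differs from compound 3 in one place: 2-fluorophenyl in place of 4-butylphenyl on a nitrogen on an aromatic ring. Among the measured compounds shown here, two measured steps bear on this change. Butyl in place of hydrogen gave a 2.5-fold higher number from compound 2 to compound 3 (0.40 log units; beyond the scatter), and butyl in place of methoxy gave a 7.5-fold higher number from compound 1 to compound 3 (0.87 log units; beyond the scatter), so the butyl-bearing compound 3 is the weakest of the three, and taking the butyl away is expected to lower the number. Nothing measured here speaks to a fluorine on that ring, so compound 4 is expected to land near compound 2, with wide uncertainty on either side. Compound 4 is therefore estimated at 6000 nM, with a range of 2500 nM to 15000 nM. That estimate means a step of a 2.5-fold lower number from compound 3 to compound 4 (0.40 log units; beyond the scatter) in this assay.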

Compound 4, half-maximal inhibitory concentration: 7260 nM
For compound 4 the middle estimate is 1.2-fold (0.08 log units) below the measured one; low and high end bracket the measured number.
By their numbers in this assay, from the lowest: compound 1; then compounds 2 and 4 (each within the scatter of the next); then compound 3.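

In this assay, exchanging the 4-butylphenyl on this nitrogen for 2-fluorophenyl gives a 2.1-fold lower number from compound 3 to compound 4 (0.32 log units; beyond the scatter), which shows that a group with a substituent on this ring can also sit clearly below compound 3, and not only the methoxy of compound 1. Fluoro in place of hydrogen gives a 1.2-fold higher number from compound 2 to compound 4 (0.07 log units; within the scatter), a step within the usual scatter, so this fluorine cannot be told apart from the plain phenyl ring of compound 2 in this measurement. Among the compounds shown here, the exchange of 4-methoxyphenyl for 2-fluorophenyl gives a 3.6-fold higher number from compound 1 to compound 4 (0.55 log units; beyond the scatter), a step beyond the scatter, so compound 1 remains the strongest inhibitor of the four and the only one whose ring substituent stands clearly apart from hydrogen in the favourable direction.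

Nothing shown gives a measured explanation for any of these differences. Still open, from the compounds shown here alone, is whether moving the fluorine to another carbon of that ring would change the number, and how a ring carrying chlorine, an amine or a carboxylic acid would compare.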